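Moving a methoxy group and cytotoxicity in hamster cells

The source may hold more compounds than are shown below. What is called first, only, known or untested is meant among the compounds shown, and "the series" means these compounds.

Measured in an ADME assay on CHO-K1 cells (Cricetulus griseus) for cytotoxicity, read by MTT assay, with a stated time of 24 h; on this read-out higher numbers stand for weaker inhibition and lower numbers for stronger inhibition:
- compound 1 `O=[N+]([O-])c1cc(-c2nnn(Cc3ccccc3)n2)cc([N+](=O)[O-])c1` gives 150000 nM
- compound 2 `O=[N+]([O-])c1cc(-c2nnn(Cc3ccccc3F)n2)cc([N+](=O)[O-])c1` gives only a limit, > 200000 nM
- compound 3 `COc1ccc(Cn2nnc(-c3cc([N+](=O)[O-])cc([N+](=O)[O-])c3)n2)cc1` gives 96000 nM

Compound 3 holds the lowest of the two numbers, but its nearest neighbour is compound 1, and the step of a 1.6-fold lower number from compound 1 to compound 3 (0.19 log units; within the scatter) stays within the scatter, so the two cannot be ordered. Compound 2 sits at a limit of the assay, (the limit of > 200000 nM in this assay, at which 1 of the 3 values shown sits), and gives no number.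

Compound 4 `COc1cccc(Cn2nnc(-c3cc([N+](=O)[O-])cc([N+](=O)[O-])c3)n2)c1` is compound 3 with its methoxy group moved: 3-methoxyphenyl in place of 4-methoxyphenyl on a saturated chain carbon bound to an aromatic nitrogen. Within the data shown here, two measured steps touch this region. Adding a methoxy group, a 1.6-fold lower number from compound 1 to compound 3 (0.19 log units; within the scatter), changed nothing beyond the scatter, while exchanging the whole aryl group, an at least 2.0-fold lower number from compound 2 to compound 3 (0.31 log units; beyond the scatter), was at least modest, though it starts from a limit. Among the measured compounds shown here, no measured step moves a methoxy group from one ring position to another, so for compound 4 the expected step of a 1.0-fold higher number from compound 3 to compound 4 (0.02 log units; within the scatter) in this assay is none beyond the scatter. Compound 4 is therefore estimated at 100000 nM, with a range from 50000 nM to 200000 nM.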

Compound 4, half-maximal inhibitory concentration: > 100000 nM
Compound 4 was reported as a limit; the forecaster's own chance of this, stated with the estimate: 20%; the middle value lies on the limit itself.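

In this assay, compound 4 is the first compound to show what happens when the methoxy group changes its place on the ring, but compound 4 returns a limit rather than a number: the limit of > 100000 nM in this assay, at which 1 of the 4 values shown sits.

Read against compound 3, the result is an at least 1.0-fold higher number from compound 3 to compound 4 (0.01 log units; that floor lies within the scatter). Exchanging 4-methoxyphenyl for 3-methoxyphenyl on a saturated chain carbon bound to an aromatic nitrogen therefore shows no change beyond the scatter, yet it does not prove that the two isomers match, as the real number for compound 4 could lie close to that of compound 3 or well above it. The steps to compound 4 from compound 1 and from compound 2 cannot be read at all.

The compounds shown leave open whether the ring position of the methoxy group matters in this cytotoxicity read-out, a question that only a real number for compound 4 could settle. They also leave open how the same ring would read with an amine or a carboxylic acid in place of the methoxy group, or how a longer chain would read in place of the single saturated carbon that joins this ring to the core.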